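Fluoro for Formyl on a Shared Core

This account rests on a few compounds, and the source may have more. Where it says the series, first, only, none or still open, it means among the compounds named here.

Compound 1 `Brc1cn2ccnc2c(-c2ccc3ncn(C4CCCCC4)c3c2)n1` and compound 2 `O=Cc1ccc(-c2cn3ccnc3c(-c3ccc4ncn(C5CCCCC5)c4c3)n2)cc1` share a core and differ in one place. In a functional assay on PC-3 cells (Homo sapiens) for inhibition, read by sulforhodamine B assay, with a stated time of 48 h, tested at 10 uM (on this read-out lower numbers stand for less inhibition and higher numbers for more inhibition at the one concentration tested (going by the name of the read-out)), compound 1 gives 17.2%, and compound 2 gives 19%. The step of a number 1.8 percentage points higher from compound 1 to compound 2 (within the scatter) came with 4-formylphenyl in place of bromo on an aromatic carbon. Compound 2 therefore holds the higher of the two numbers, but its gap to compound 1 is within the scatter, so no order between them can be read from these data.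

Compound 3 `Fc1ccc(-c2cn3ccnc3c(-c3ccc4ncn(C5CCCCC5)c4c3)n2)cc1` has not yet been measured. It differs from compound 2 by fluoro in place of formyl on an aromatic carbon. Among the compounds with values here, the only measured step, a number 1.8 percentage points higher from compound 1 to compound 2 (within the scatter), concerned a different exchange and stayed within the scatter; it bears on the present change only loosely, and nothing else in the data points in either direction. The expected step is therefore a number 2 percentage points lower from compound 2 to compound 3 (within the scatter), which lies within the scatter. On that basis compound 3 is estimated at 17% in this assay, with a range from 5% to 30%.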

Compound 3, a percentage reported as inhibition, at one concentration (the size of the read-out at that concentration, not a potency): 53.6%
Compound 3: middle estimate off by 36.6 percentage points, on the low side; measured number outside the range, above it.
By their numbers in this assay, from the lowest: compounds 1 and 2 (each within the scatter of the next); then compound 3.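

In this assay, within the data shown here, fluoro in place of formyl on an aromatic carbon, para to a large group, went with a number 34.6 percentage points higher from compound 2 to compound 3 (beyond the scatter), the first step in this small set to lie beyond the scatter. It shows that the read-out responds strongly to the group at this single carbon, which the earlier exchange of bromo for 4-formylphenyl could not show, as that step stayed within the scatter. With 4-fluorophenyl in place of bromo there is a number 36.4 percentage points higher from compound 1 to compound 3 (beyond the scatter), so a phenyl ring at this place does not set the number by itself, and the two phenyl compounds part only through formyl and fluoro, while no data here bear on what lies behind the difference.

The compounds shown leave open whether the higher number belongs to fluoro itself or to the loss of formyl, a question that an unsubstituted phenyl, a 4-chlorophenyl, a 4-methoxyphenyl or a 4-aminophenyl group at the same place would help to settle. On these data alone, the read-out gives the size of the inhibition at one concentration and not a potency, so the potency of compound 3 also remains open.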